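The source may report more compounds than this note shows. Statements on the series, on what has been measured and on what is new or still open speak of the compounds shown alone.

Measured so far in a toxicity assay on HeLa cells (Homo sapiens) for cytotoxicity, read by MTT assay, with a stated time of 24 h; on this read-out lower numbers stand for stronger inhibition and higher numbers for weaker inhibition
compound 1 `CCOC(=O)N1CCN(C(=S)SCC(O)Cn2c([N+](=O)[O-])cnc2C)CC1` gives 1610000 nM
compound 2 `Cc1ncc([N+](=O)[O-])n1CC(O)CSC(=S)N1CCN(c2cccc(Cl)c2)CC1` gives 1080000 nM
compound 3 `CCOC(=O)N1CCN(C(=S)SCC(O)Cn2cc([N+](=O)[O-])nc2C)CC1` is not yet measured

Among the measured compounds shown here, on these numbers compound 1 stands level with compound 2, the only other measured compound, since the step is a 1.5-fold lower number from compound 1 to compound 2 (0.17 log units; within the scatter) and lies within the scatter. That step swaps ethoxycarbonyl for 3-chlorophenyl on an amine nitrogen in a ring, so it leaves untouched the group that changes next.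

Compound 3 has the same atoms as compound 1, joined differently: 2-methyl-4-nitro-1H-imidazol-1-yl in place of 2-methyl-5-nitro-1H-imidazol-1-yl on a saturated chain carbon, two bonds along the chain from an oxygen on a saturated carbon on a saturated chain carbon, two bonds along the chain from an oxygen on a saturated carbon. For the measured compounds named here, no measured step tests this swap directly, so no shift beyond the scatter is expected in this assay, in either direction. The estimated step is a 1.1-fold lower number from compound 1 to compound 3 (0.03 log units; within the scatter) and nothing more. For compound 3 the expected value is 1500000 nM with an estimated range of 650000 nM to 3200000 nM as the likely span.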

Compound 3, half-maximal inhibitory concentration: 2360000 nM
Compound 3: middle estimate off by 1.6-fold (0.20 log units), on the low side, and the stated range covers the measured number.
By their numbers in this assay, from the lowest: compounds 2, 1 and 3 (each within the scatter of the next, the first and the last beyond it).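

In this assay, placing 2-methyl-4-nitro-1H-imidazol-1-yl where compound 1 carries 2-methyl-5-nitro-1H-imidazol-1-yl gives a 1.5-fold higher number from compound 1 to compound 3 (0.17 log units; within the scatter), so this pair of isomers cannot be told apart on this read-out. Among the compounds shown here, the earlier step changed only the group on the ring amine nitrogen, whereas this one is the first to test the nitro-bearing group on the saturated chain carbon, and the rearrangement leaves the number within the scatter. No measured evidence bears on this result.

On these data alone, this reading rests on a single pair with ethoxycarbonyl on the ring nitrogen, so it remains open whether the same swap would behave alike with 3-chlorophenyl there. Also open, as far as these compounds go, is whether a nitrile in place of the nitro group, or an ethyl in place of the ring methyl, would move the number beyond the scatter.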